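Two weak inhibitors, and a halogen swap on the benzyl group

This account rests on a few compounds, and the source may have more. Where it says the series, first, only, none or still open, it means among the compounds named here.

Compound 1 `CC(C)(C)c1cc(CCC(=O)NC2CCN(Cc3ccccc3)CC2)cc(C(C)(C)C)c1O`: 80300 nM
Compound 2 `COc1ccc(CN2CCC(CCNC(=O)/C=C/c3cc(C(C)(C)C)c(O)c(C(C)(C)C)c3)CC2)cc1`: 61200 nM

The series is read in a functional assay, read by spectrophotometry, with a stated time of 30 min; on this read-out lower numbers stand for stronger inhibition and higher numbers for weaker inhibition. Compound 1 gives 80300 nM, and compound 2 gives 61200 nM. Compound 2 holds the lowest of the two numbers, but the gap to compound 1 is within the scatter of repeated measurements, so the two compounds cannot be told apart on these data. Both are weak by this read-out.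

Compound 3 `CC(C)(C)c1cc(/C=C/C(=O)NCCC2CCN(Cc3ccc(F)cc3F)CC2)cc(C(C)(C)C)c1O` has not yet been measured. It differs from compound 2 in a single place: 2,4-difluorophenyl in place of 4-methoxyphenyl on a saturated chain carbon bound to an amine nitrogen in a ring. The rest of the molecule, from the hindered phenol through the unsaturated amide linker to the piperidine, is unchanged.

For the measured compounds named here, no step between two measured compounds is known here, so there is nothing to calibrate the size of this change against. With no measured comparison of this kind, the expectation for compound 3 rests on compound 2 at 61200 nM and is for a step of a 1.1-fold lower number from compound 2 to compound 3 (0.05 log units; within the scatter) that stays within the scatter. Compound 3 is therefore estimated at 55000 nM, with a range from 18000 nM to 160000 nM.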

Compound 3, half-maximal inhibitory concentration: 62400 nM
Compound 3: the middle estimate sits 1.1-fold (0.05 log units) below what was measured, within the range that was stated.
By their numbers in this assay, from the lowest: compounds 2, 3 and 1 (each within the scatter of the next).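

In this assay, for the compounds shown here, placing 2,4-difluorophenyl where 4-methoxyphenyl stood, on a saturated chain carbon bound to an amine nitrogen in a ring, gives a 1.0-fold higher number from compound 2 to compound 3 (0.01 log units; within the scatter), the first one-place step, and the two compounds cannot be told apart. At this place, then, two groups of 8 heavy atoms, one with an oxygen and 1 hydrogen-bond acceptor and the other with two fluorines and 0 hydrogen-bond acceptors, read alike on this single pair, and both compounds remain weak by this read-out. No measurement is available that could explain this lack of separation.

Going by these compounds, whether this place tolerates every group equally remains open, since a single pair says nothing about how a carboxylic acid, a dimethylamino group or a longer chain in place of the 2,4-difluorobenzyl group would read. The hindered phenol and the amide linker also remain unresolved, as compound 1 differs from compound 2 in more than one place and no single change can be read from that pair.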